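Series notes: fluoro to bromo step toward compound 3

The source may hold more compounds than are shown below. What is called first, only, known or untested is meant among the compounds shown, and "the series" means these compounds.

Measured so far:
compound 1 `CC(=O)c1ccc(OCc2cccc([N+](=O)[O-])c2)cc1`: 104 nM
compound 2 `CC(=O)c1ccc(OCc2cccc(F)c2)cc1`: 83.1 nM

In an assay on isolated protein for inhibition of Amine oxidase [flavin-containing] B (Homo sapiens), read by Amplex Red, with a stated time of 15 min (a lower number here means a stronger inhibitor, a higher number a weaker inhibitor), compound 2 sits at the lower end of the two numbers, with compound 1 the nearest value; the step of a 1.3-fold lower number from compound 1 to compound 2 (0.10 log units; within the scatter) lies within the scatter, so the two compounds are not separated by this assay. Compound 3 `CC(=O)c1ccc(OCc2cccc(Br)c2)cc1` is not yet measured. It differs from compound 2 by bromo in place of fluoro on an aromatic carbon. Within the data shown here, no measured step covers this exchange of one halogen for another; the only step in hand, a 1.3-fold lower number from compound 1 to compound 2 (0.10 log units; within the scatter), concerns a different group and was itself within the scatter. The expectation for compound 3 in this assay therefore rests on the shared core alone, and a step of modest size is expected, not firmly beyond the scatter in either direction. Compound 3 is estimated at 55 nM with a range of 15 nM to 200 nM. This estimate means an expected step of a 1.5-fold lower number from compound 2 to compound 3 (0.18 log units; within the scatter).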

Compound 3, half-maximal inhibitory concentration: 214 nM
Estimate against measurement, compound 3: 3.9-fold (0.59 log units) below; measured number above the stated range.
By their numbers in this assay, from the lowest: compounds 2 and 1 (each within the scatter of the next); then compound 3.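

In this assay, this position on the aromatic ring now proves sensitive to the substituent: bromo in place of fluoro gives a 2.6-fold higher number from compound 2 to compound 3 (0.41 log units; beyond the scatter), whereas the earlier exchange of nitro for fluoro stayed within the scatter. Bromo in place of nitro gives a 2.1-fold higher number from compound 1 to compound 3 (0.31 log units; beyond the scatter), so among the three groups tested here, bromo alone stands apart, with the higher number, while fluoro and nitro remain unseparated. No measurement at hand bears on what lies behind this difference.

As far as these compounds go, it remains open whether chloro or iodo at this place would group with fluoro or with bromo, and whether an amine or a methoxy group would be tolerated as fluoro and nitro are. Also open, from the compounds shown here alone, is whether bromo in place of fluoro would give a similar step elsewhere on the shared core.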